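Series notes: from compound 2 to compound 4

The source may report more compounds than this note shows. Statements on the series, on what has been measured and on what is new or still open speak of the compounds shown alone.

Measured so far in an assay on isolated protein for inhibition of aldehyde dehydrogenase 1A1 (Homo sapiens), read by spectrophotometry, tested at 10 uM; on this read-out lower numbers stand for less inhibition and higher numbers for more inhibition at the one concentration tested (going by the name of the read-out):
compound 1 `Cc1cccc(Cn2c(CN3CCN(C(=O)c4ccc(C#N)cc4)CC3)nc3ccccc32)c1` gives 20.8%
compound 2 `O=C(C1CC1)N1CCN(Cc2nc3ccccc3n2Cc2ccc(F)cc2)CC1` gives 32.7%
compound 3 `COc1ccc(C(=O)N2CCN(Cc3nc4ccccc4n3Cc3cccc(C)c3)CC2)cc1` gives 55.5%

Compound 2 stands second highest of the three numbers in this assay. Compound 3 stands higher than compound 2, beyond the scatter, and compound 1 stands lower than compound 2, beyond the scatter. Within the data shown here, the only single-point step within the measured set, a number 34.7 percentage points higher from compound 1 to compound 3 (beyond the scatter), is a change of the substituent on the aryl amide, and it is large.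

Compound 4 `O=C(C1CC1)N1CCN(Cc2nc3ccccc3n2Cc2ccc(C(F)(F)F)cc2)CC1` differs from compound 2 in one place: trifluoromethyl in place of fluoro on an aromatic carbon. Put another way, 4-fluorophenyl becomes 4-(trifluoromethyl)phenyl. Among the measured compounds shown here, no measured pair shows this change, and the one measured step sits on the other end of the shared core, so nothing in the set speaks directly to the size or direction of the step in this assay for this change. The working expectation is therefore a step from compound 2 to compound 4 of no clear size beyond the scatter, written as a number 2.3 percentage points higher from compound 2 to compound 4 (within the scatter), with a wide range to cover either direction.

On that basis compound 4 is estimated at 35% in this assay, with a range from 15% to 55%.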

Compound 4, a percentage reported as inhibition, at one concentration (the size of the read-out at that concentration, not a potency): 37%
Beside the measured number, compound 4's estimate is 2 percentage points below it; measured number inside the range.
By their numbers in this assay, from the lowest: compound 1; then compounds 2 and 4 (each within the scatter of the next); then compound 3.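

In this assay, among these compounds, the change from 4-fluorophenyl to 4-(trifluoromethyl)phenyl gives the first reading at this end of the shared core: (a number 4.3 percentage points higher from compound 2 to compound 4 (within the scatter)). Among the compounds shown here, on an aromatic carbon para to a large group, four heavy atoms thus stand in place of one without a step beyond the scatter, whereas the only earlier step (a number 34.7 percentage points higher from compound 1 to compound 3 (beyond the scatter)) is large and belongs to a substituent change on the aryl amide at the other end of the core. No accompanying measurement offers any account of this reading.

Fluoro and trifluoromethyl are the only two groups read at this position, so it remains open whether an amine, a carboxylic acid or a longer alkyl chain there would also stay within the scatter of compound 2. As far as these compounds go, it also remains open whether the same change would read the same way with the aryl amides of compound 1 and compound 3 in place of the amide of compound 2, and, with only one tested concentration, how potency would compare.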